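The compounds below may be only part of what the source reports. "The series", "measured", "known", "first", "only" and "open" are said of these compounds alone.

Of the compounds shown here, three in this set have been measured and one has not. In a functional assay on LM7 cells (Homo sapiens) for antiproliferative activity, read by MTT assay, with a stated time of 72 h (on this read-out lower numbers stand for stronger inhibition and higher numbers for weaker inhibition), compound 1 `COc1ccc2occ(CSC(=S)N3CCCCC3)c(=O)c2c1` gives 4700 nM, the lowest number of the three, although the others lie within the usual scatter of it. Compound 3 `COc1ccc2oc(CSC(=S)N3CCCCC3)cc(=O)c2c1` gives 5000 nM in this assay, and compound 2 `CCN(CC)C(=S)SCc1cc(=O)c2ccc(Cl)cc2o1` gives 8800 nM; neither of these values is distinguished from that of compound 1 once the scatter of repeated measurements is taken into account, so this assay does not separate the three.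

Compound 4 `COc1ccc2occ(CSC(=S)N3CCOCC3)c(=O)c2c1` has not yet been measured. It differs from compound 1 in one place: morpholin-4-yl in place of piperidin-1-yl on a thiocarbonyl carbon. Going by the values given here, no measured pair in the set shows the effect of such a change, so the expectation for compound 4 rests on the closely spaced values of the three measured compounds and on the small size of the change. A step in this assay no larger than the scatter, with no clear direction, is expected, and the expected step is a 1.3-fold higher number from compound 1 to compound 4 (0.11 log units; within the scatter). Compound 4 is estimated to give 6000 nM in this assay, with a range from 2500 nM to 15000 nM.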

Compound 4, half-maximal inhibitory concentration: > 40000 nM
Compound 4: only a limit was reported (the forecaster's own chance of this, stated with the estimate: 5%); middle value at least 6.6-fold (0.82 log units) from the limit.
By their numbers in this assay, from the lowest: compounds 1, 3 and 2 (each within the scatter of the next). At a limit, above all of these: compound 4.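

In this assay, the place on the thiocarbonyl carbon proves sensitive to the exchange of one six-membered ring for another: morpholin-4-yl in place of piperidin-1-yl gives an at least 8.5-fold higher number from compound 1 to compound 4 (0.92 log units; beyond the scatter), a separation that the three earlier compounds, all within the scatter of one another, did not provide. The value of compound 4, > 40000 nM, is a limit of the assay and not a number. The size of this step is therefore bounded on one side only: the limit of > 40000 nM in this assay, at which 1 of the 4 values shown sits.

The compounds shown leave open whether other amines at this place, such as pyrrolidin-1-yl or 4-methylpiperazin-1-yl, would stay close to compound 1 or fall away as compound 4 does. They also leave open whether morpholin-4-yl would have a similar effect on the core of compound 3.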